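The compounds below may be only part of what the source reports. "The series", "measured", "known", "first", "only" and "open" are said of these compounds alone.

Measured compounds:
compound 1, `COc1ncc(-c2nc(C(F)(F)F)sc2N2CCN(C(=O)Cn3cnc4cccnc43)[C@H](C)C2)cn1`, 3.8 nM
compound 2, `COc1ncc(-c2nc(C(F)(F)F)sc2N2CCN(C(=O)Cn3nc(C)nc3C)[C@H](C)C2)cn1`, 25 nM

In a functional assay on CHO-K1 cells for antagonist activity at C-X-C chemokine receptor type 3 (Homo sapiens), read by FLIPR, with a stated time of 10 min (a higher number here means a weaker inhibitor, a lower number a stronger inhibitor), compound 1 gives 3.8 nM and compound 2 gives 25 nM; the step of a 6.6-fold higher number from compound 1 to compound 2 (0.82 log units; beyond the scatter) is the only one measured. Compound 2 thus stands at the higher of the two numbers, the weaker inhibitor of the pair.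

Compound 3, `CCCc1ncc(-c2nc(C(F)(F)F)sc2N2CCN(C(=O)Cn3nc(C)nc3C)[C@H](C)C2)cn1`, keeps the amide-linked five-membered aromatic ring of compound 2 and differs only at the far end of the shared core: propyl in place of methoxy on an aromatic carbon. Within the data shown here, the single measured step concerns the group on the saturated chain carbon bound to the carbonyl carbon and does not touch this position, so nothing measured bears on the exchange. Without a comparable step, the expectation is a change that may not clear the scatter, with a slight lean toward a higher number, estimated as a 1.4-fold higher number from compound 2 to compound 3 (0.15 log units; within the scatter). Compound 3 is therefore estimated at 35 nM, with a range from 10 nM to 120 nM.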

Compound 3, half-maximal inhibitory concentration: 4.4 nM
Estimate against measurement, compound 3: 8.0-fold (0.90 log units) above; measured number below the stated range.
By their numbers in this assay, from the lowest: compounds 1 and 3 (each within the scatter of the next); then compound 2.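

In this assay, the aromatic carbon between two ring nitrogen atoms proves to be a position that moves the number: a 5.7-fold lower number from compound 2 to compound 3 (0.75 log units; beyond the scatter), with propyl in place of methoxy. Among these compounds, until now, the only measured change lay on the saturated chain carbon bound to the carbonyl carbon, so this step is the first to show that the far end of the shared core also matters. The exchange removes the hydrogen-bond acceptor counted for methoxy, and the number still falls, so that acceptor is not required for a low number with the amide-side group of compound 2. The data offer no measured basis for explaining this step.

From the compounds shown here alone, whether ethyl, butyl or a dimethylamino group at this position would match propyl remains open. So does whether propyl would lower the number when paired with the amide-side group of compound 1.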